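The source may hold more compounds than are shown below. What is called first, only, known or untested is meant among the compounds shown, and "the series" means these compounds.

Compound 1, `C=C(C)C(=O)Nc1cccc(-c2nc3ccccc3s2)c1` — > 25000 nM
Compound 2, `CC(Cl)C(=O)Nc1cccc(-c2nc3ccccc3s2)c1` — > 25000 nM

Of the compounds shown here, two with a shared core have been measured in an ADME assay on HepG2 cells (Homo sapiens) for inhibition, with a stated time of 72 h; a higher number here means that more compound is needed for the effect, a lower number that less compound is needed. In this assay compound 1 gives > 25000 nM, which is a limit of the assay and not a number. In this assay compound 2 gives > 25000 nM, again a limit rather than a number. Within the data shown here, the one step between them, a step that the two limits leave unreadable from compound 1 to compound 2, cannot be read because both values sit at the limit of > 25000 nM in this assay, at which 2 of the 2 values shown sit. Among the measured compounds shown here, compound 2 therefore stands only at a limit, and the single other value shown is a limit as well.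

Compound 3, `O=C(Nc1cccc(-c2nc3ccccc3s2)c1)c1ccncc1Cl`, differs from compound 2 in one place: 3-chloropyridin-4-yl in place of 1-chloroethyl on a carbonyl carbon. For the measured compounds named here, the only measured step that bears on this change is the unreadable one from compound 1 to compound 2, so it gives no size and no direction for the step in this assay. Compound 3 is accordingly expected to show a step that the limit leaves unreadable from compound 2 to compound 3, most likely ending at another limit. The estimate for compound 3 in this assay is 30000 nM, within a range from 8000 nM to 100000 nM.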

Compound 3, half-maximal effective concentration: > 25000 nM
Compound 3 ended at the assay's limit (the forecaster's own chance of this, stated with the estimate: 80%); the middle value lies beyond the limit too.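

In this assay compound 3 gives > 25000 nM, a limit of the assay and not a number. No step among compound 1, compound 2 and compound 3 can be read, as all three values stand at the same limit: the limit of > 25000 nM in this assay, at which 3 of the 3 values shown sit.

The compounds shown leave open whether any group on the carbonyl carbon of the shared core changes the value in this assay, and in which direction.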